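The source may hold more compounds than are shown below. What is called first, only, known or untested is meant among the compounds shown, and "the series" means these compounds.

Among the measured compounds shown here, compound 2 `CCc1ccc(NS(=O)(=O)c2ccc(N3CCNC3=O)cc2)cc1` is the weaker of the two compounds measured so far: in a functional assay on M21 cells (Homo sapiens) for antiproliferative activity, read by sulforhodamine B assay, with a stated time of 48 h (on this read-out higher numbers stand for weaker inhibition and lower numbers for stronger inhibition), compound 2 gives 480 nM, the highest of the two numbers. For the measured compounds named here, its only comparator is compound 1 `CCc1ccccc1NS(=O)(=O)c1ccc(N2CCNC2=O)cc1`, which in this assay gives 180 nM. Going by the values given here, the single measured step between them, a 2.7-fold higher number from compound 1 to compound 2 (0.43 log units; beyond the scatter), is the only one that bears on compound 3 `COc1ccccc1NS(=O)(=O)c1ccc(N2CCNC2=O)cc1`. Compound 3 differs from compound 2 by 2-methoxyphenyl in place of 4-ethylphenyl on a sulfonamide nitrogen. The change has two parts. First, a 2-substituted phenyl, as in the 2-ethylphenyl of compound 1, takes the place of the 4-substituted phenyl of compound 2, and the step of a 2.7-fold higher number from compound 1 to compound 2 (0.43 log units; beyond the scatter) read in reverse suggests this should lower the number. Second, ethyl is exchanged for methoxy, and for that exchange no measured comparison exists, so its effect cannot be judged. On the first part alone, compound 3 is expected to show a modestly lower number than compound 2, about a 2.4-fold lower number from compound 2 to compound 3 (0.38 log units; beyond the scatter). The estimate for compound 3 in this assay is 200 nM, with a range from 70 nM to 600 nM.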

Compound 3, half-maximal inhibitory concentration: 300 nM
Compound 3: middle estimate off by 1.5-fold (0.18 log units), on the low side; measured number inside the range.
By their numbers in this assay, from the lowest: compounds 1, 3 and 2 (each within the scatter of the next, the first and the last beyond it).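

In this assay the exchange of ethyl for methoxy on an aromatic carbon, which had no measured comparison before, now has one: it gives a 1.7-fold higher number from compound 1 to compound 3 (0.22 log units; within the scatter) and so leaves the two groups within the scatter of each other on this 2-substituted phenyl. The change to 2-methoxyphenyl from 4-ethylphenyl on the sulfonamide nitrogen gives a 1.6-fold lower number from compound 2 to compound 3 (0.20 log units; within the scatter) and so, unlike a 2.7-fold higher number from compound 1 to compound 2 (0.43 log units; beyond the scatter) among the two ethyl compounds, does not yield a step beyond the scatter, which means that the two new steps together fix no order for compound 3 against either earlier compound. Nothing measured here offers an explanation for any of these steps.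

The compounds shown leave open whether an amine, a carboxylic acid or a longer chain in place of the methoxy of compound 3 would give a number clearly apart from those of the ethyl and methoxy compounds. Also open, from the compounds shown here alone, is whether the gap seen between the two ethyl compounds recurs when methoxy sits elsewhere on the phenyl ring.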